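A few compounds are considered here, and "the series" means these few. Any claim that something is new, unique, unknown or untested is made for them only; others in the source may bear on it.

Measured so far:
compound 1, `COc1cc(N(Cc2ccc(C)cc2)C(=O)CSc2nc3ccccc3s2)cc(OC)c1OC`: > 80000 nM
compound 2, `COc1ccc(CN(C(=O)CSc2nc3ccccc3s2)c2cc(OC)c(OC)c(OC)c2)cc1O`: 182 nM

In a functional assay on HCT-116 cells (Homo sapiens) for antiproliferative activity, read by MTT assay, with a stated time of 48 h (a lower number here means a stronger inhibitor, a higher number a weaker inhibitor), compound 1 gives > 80000 nM, which is a limit of the assay and not a number; it is the limit of > 80000 nM in this assay, at which 1 of the 2 values shown sits. Compound 2 gives 182 nM. Among the measured compounds shown here, the one measured step, an at least 430-fold lower number from compound 1 to compound 2 (2.64 log units; beyond the scatter), comes from putting 3-hydroxy-4-methoxyphenyl in place of 4-methylphenyl on a saturated chain carbon bound to an amide-type nitrogen.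

Compound 3, `COc1cc(N(Cc2ccc(F)cc2)C(=O)CSc2nc3ccccc3s2)cc(OC)c1OC`, is not yet measured. It differs from compound 1 by fluoro in place of methyl on an aromatic carbon. For the measured compounds named here, no measured step bears directly on this change: the step from compound 1 to compound 2 exchanges the whole 4-methylphenyl and cannot be split into a part owed to the methyl alone. The starting point is also only a limit, since compound 1 gives > 80000 nM. On these numbers a fluoro for methyl swap is expected to leave compound 3 near where compound 1 stands, with no step beyond the scatter, an at least 1.3-fold lower number from compound 1 to compound 3 (0.12 log units; that floor lies within the scatter), and a fair chance of another limit. Compound 3 is therefore estimated at 60000 nM, within 4000 nM to 100000 nM.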

Compound 3, half-maximal inhibitory concentration: 59800 nM
Beside the measured number, compound 3's estimate is 1.0-fold (0.00 log units) above it; low and high end bracket the measured number.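

In this assay, fluoro in place of methyl on the aromatic carbon gives an at least 1.3-fold lower number from compound 1 to compound 3 (0.12 log units; that floor lies within the scatter) and so does not separate the two groups, leaving the true size of this change unsettled. Compound 3 does supply a measured number for a simple 4-fluorobenzyl group, yet that group remains far from the group in compound 2, with a 330-fold higher number from compound 2 to compound 3 (2.52 log units; beyond the scatter) as a second large step at the same place, so the weak result is now seen with both the 4-methylphenyl and the 4-fluorophenyl groups and compound 2 stands apart from both. Compound 1 remains a limit of the assay and not a number: the limit of > 80000 nM in this assay, at which 1 of the 3 values shown sits.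

The compounds shown do not tell whether the hydroxy or the methoxy group of compound 2 carries the gain, as each step exchanges the whole aromatic ring. A 3-hydroxyphenyl group, a 4-methoxyphenyl group or a 3-aminophenyl group at this place would divide that step into its parts.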